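Chlorine on the benzoyl ring of compound 2

This account rests on a few compounds, and the source may have more. Where it says the series, first, only, none or still open, it means among the compounds named here.

Measured compounds and their values:
compound 1 `CC(=O)OC/C(=C\c1ccc(Cl)cc1Cl)C(=O)c1ccccc1`: 14000 nM
compound 2 `CC(=O)OC/C(=C/c1ccc(Cl)cc1Cl)C(=O)c1ccccc1`: 19000 nM
compound 3 `O=C(OC/C(=C/c1ccc(Cl)cc1Cl)C(=O)c1ccccc1)c1ccccc1`: 8700 nM

In a functional assay on WiDr cells (Homo sapiens) for inhibition, read by sulforhodamine B assay, with a stated time of 48 h (on this read-out lower numbers stand for stronger inhibition of growth and higher numbers for weaker inhibition of growth), compound 2 gives the highest number of the three. Compound 1 stands nearest, the step of a 1.4-fold higher number from compound 1 to compound 2 (0.13 log units; within the scatter) lying within the scatter, which fits (the fact that compounds 1 and 2 differ only in the configuration as drawn). Compound 3 stands furthest, with a 2.2-fold lower number from compound 2 to compound 3 (0.34 log units; beyond the scatter).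

Compound 4 `CC(=O)OC/C(=C/c1ccc(Cl)cc1Cl)C(=O)c1ccc(Cl)cc1` differs from compound 2 by chloro in place of hydrogen on an aromatic carbon. Neither measured step touches that ring: one concerns configuration, the other the ester. Among the measured compounds shown here, no measured step therefore bears on this change, and no step beyond the scatter is expected in this assay, with the estimated step of a 1.3-fold lower number from compound 2 to compound 4 (0.10 log units; within the scatter). For compound 4 the estimated value is 15000 nM, expected between 6000 nM and 40000 nM.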

Compound 4, concentration for 50% growth inhibition: 20000 nM
For compound 4 the middle estimate is 1.3-fold (0.12 log units) below the measured one; low and high end bracket the measured number.
By their numbers in this assay, from the lowest: compounds 3, 1, 2 and 4 (each within the scatter of the next, the first and the last beyond it).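

In this assay, the first change shown on this ring, phenyl to 4-chlorophenyl, gives a 1.1-fold higher number from compound 2 to compound 4 (0.02 log units; within the scatter) and so leaves the number where it stood. At this place, then, chloro can replace hydrogen without a step beyond the scatter, whereas the change on the ester carbonyl did produce one. Nothing in the available evidence bears on this result. Still open, from the compounds shown here alone, is whether an amine, a carboxylic acid or a longer chain at this place would shift the number, and whether chloro behaves alike in compound 1 or compound 3.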